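This account rests on a few compounds, and the source may have more. Where it says the series, first, only, none or still open, it means among the compounds named here.

Working notes on the series. The shared core is shown by compound 1 `CC1=CC[C@H](C(C)(C)NC(=S)N/N=C/c2ccccc2)CC1`; the compounds differ only in the group on the carbon with a double bond to nitrogen. In a functional assay on K562 cells (Homo sapiens) for inhibition, read by sulforhodamine B assay, with a stated time of 48 h (on this read-out lower numbers stand for stronger inhibition of growth and higher numbers for weaker inhibition of growth), compound 1 gives 47600 nM. Compound 2 `CC1=CC[C@H](C(C)(C)NC(=S)N/N=C/c2cccc(Cl)c2)CC1` adds chloro in place of hydrogen on an aromatic carbon, and for compound 2 this assay reports only a limit, > 100000 nM. The step of an at least 2.1-fold higher number from compound 1 to compound 2 (0.32 log units; beyond the scatter) is therefore bounded, in keeping with the limit of > 100000 nM in this assay, at which 1 of the 3 values shown sits. Compound 3 `CC1=CC[C@H](C(C)(C)NC(=S)N/N=C/c2ccc(Cl)cc2)CC1` carries 4-chlorophenyl rather than 3-chlorophenyl, and in this assay compound 3 gives 16900 nM, the lowest of the two numbers given; the step runs a 2.8-fold lower number from compound 1 to compound 3 (0.45 log units; beyond the scatter), and an at least 5.9-fold lower number from compound 2 to compound 3 (0.77 log units; beyond the scatter). Compound 4 `CC1=CC[C@H](C(C)(C)NC(=S)N/N=C/c2ccco2)CC1` is not yet measured. Its change from compound 3 is furan-2-yl in place of 4-chlorophenyl on a carbon with a double bond to nitrogen. Within the data shown here, no measured step exchanges the aromatic ring itself; the steps that bear on the change are the reverse of a 2.8-fold lower number from compound 1 to compound 3 (0.45 log units; beyond the scatter), which shows what the chloro contributes, and the bounded an at least 5.9-fold lower number from compound 2 to compound 3 (0.77 log units; beyond the scatter). Both point to a higher number once the 4-chlorophenyl is gone, so in this assay the expected step is a 2.7-fold higher number from compound 3 to compound 4 (0.43 log units; beyond the scatter). Compound 4 is therefore estimated in this assay at 45000 nM, ranging from 15000 nM to 100000 nM.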

Compound 4, concentration for total growth inhibition: > 100000 nM
Compound 4: a limit, no number; the forecaster's own chance of this, stated with the estimate: 20%; middle value at least 2.2-fold (0.34 log units) from the limit.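

The exchange of the aromatic ring itself, on a carbon with a double bond to nitrogen, now has a result in this assay: furan-2-yl in place of 4-chlorophenyl gives an at least 5.9-fold higher number from compound 3 to compound 4 (0.77 log units; beyond the scatter), and furan-2-yl in place of phenyl gives an at least 2.1-fold higher number from compound 1 to compound 4 (0.32 log units; beyond the scatter). The second step needs no chloro to be read, so among the compounds shown, weaker growth inhibition with furan-2-yl appears against the unsubstituted phenyl as well as against 4-chlorophenyl. Compound 4 stands at a limit of the assay, not a number, as does compound 2, and the step between them cannot be read: the limit of > 100000 nM in this assay, at which 2 of the 4 values shown sit.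

On these data alone, how far compound 4 lies beyond that limit stays open, and so does any order between furan-2-yl and 3-chlorophenyl at this position. Also open, as far as these compounds go, is whether another ring holds a number in this assay, for example a pyridine ring or thiophen-2-yl, and whether a chloro on the furan-2-yl ring would shift compound 4 as it shifts compound 1 in the step to compound 3.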